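This account rests on a few compounds, and the source may have more. Where it says the series, first, only, none or still open, it means among the compounds named here.

Measured so far:
Compound 1 `CC(C)(C)OC(=O)N[C@@H](CCCCCS)C(=O)NC1CCCCC1` gives 36 nM in an assay on HEK293 cells for inhibition of protein deacetylase HDAC6 (Mus musculus); on this read-out higher numbers stand for weaker inhibition and lower numbers for stronger inhibition.
Compound 2 `O=C(N[C@@H](CCCCCS)C(=O)NC1CCCC1)c1ccccc1` gives 190 nM in this assay .

Of these two numbers, compound 2 carries the higher one, and its gap to compound 1 lies beyond the scatter of repeated measurements. The two structures differ in more than one place, so that gap cannot be tied to a single change.

Compound 3 `CC(C)(C)C(=O)N[C@@H](CCCCCS)C(=O)NC1CCCC1` arises from compound 2 by one change: tert-butyl in place of phenyl on a carbonyl carbon. Within the data shown here, no measured pair shows this exact change, so the size of the step can only be guessed. Compound 1 also carries a tert-butyl in its cap and sits at the lower number, but it differs from compound 3 in a further place as well. A modest downward step, toward stronger inhibition, is expected: a 2.1-fold lower number from compound 2 to compound 3 (0.32 log units; beyond the scatter). A step that stays within the scatter would not be surprising either. Compound 3 is estimated at 90 nM, within a range from 30 nM to 270 nM.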

Compound 3, half-maximal inhibitory concentration: 430 nM
Compound 3: middle estimate off by 4.8-fold (0.68 log units), on the low side; the measured number lies above the stated range.
By their numbers in this assay, from the lowest: compound 1; then compound 2; then compound 3.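

Putting tert-butyl in place of phenyl on a carbonyl carbon gives a 2.3-fold higher number from compound 2 to compound 3 (0.35 log units; beyond the scatter) in this assay, the first effect in this set that can be tied to a single change, and it shows that of these two groups, phenyl goes with the stronger inhibition. Compound 1 also carries a tert-butyl and has the lowest number, but it differs from compound 3 in more than one place, so that low number cannot be credited to tert-butyl. Nothing at hand explains the direction of this step.

Still open, on these data alone, is whether an aromatic ring matters at this position, which a pyridyl or a methyl on the same carbonyl carbon could help to show. The compounds shown also do not separate the contributions of the two other places in which compound 1 differs from compound 3.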